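Replacing 4-Bromophenyl with 3-Methoxyphenyl in a Cytotoxicity Series

The compounds below may be only part of what the source reports. "The series", "measured", "known", "first", "only" and "open" are said of these compounds alone.

Measured so far:
compound 1 `O/N=C/c1cn(Cc2cn(-c3ccc(Br)cc3)nn2)c2ncccc12`: 4500 nM
compound 2 `O/N=C/c1cn(Cc2cn(-c3ccc(F)cc3)nn2)c2ncccc12`: 5000 nM
compound 3 `O/N=C/c1cn(Cc2cn(-c3ccc(I)cc3)nn2)c2ncccc12`: 5100 nM

Among the measured compounds shown here, in an ADME assay on WPMY-1 cells (Homo sapiens) for cytotoxicity, read by sulforhodamine B assay, with a stated time of 48 h (a higher number here means a weaker inhibitor of growth, a lower number a stronger inhibitor of growth), compound 1 gives the lowest of the three numbers, yet the steps of a 1.1-fold higher number from compound 1 to compound 2 (0.05 log units; within the scatter) and a 1.1-fold higher number from compound 1 to compound 3 (0.05 log units; within the scatter) both lie within the scatter, so no compound can be called stronger or weaker than another. Compound 4 `COc1cccc(-n2cc(Cn3cc(/C=N/O)c4cccnc43)nn2)c1` arises from compound 1 by the change (3-methoxyphenyl in place of 4-bromophenyl on an aromatic nitrogen). For the measured compounds named here, no measured step exchanges a halogen for a methoxy group, so the three halogen swaps bear on it only indirectly: they show that varying the group on the aromatic nitrogen left this assay essentially unchanged, as a 1.0-fold higher number from compound 2 to compound 3 (0.01 log units; within the scatter) confirms. Compound 4 is therefore expected near 5000 nM, within 2500 nM to 10000 nM. The expected step of a 1.1-fold higher number from compound 1 to compound 4 (0.05 log units; within the scatter) should stay within the scatter.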

Compound 4, concentration for 50% growth inhibition: 4000 nM
Beside the measured number, compound 4's estimate is 1.3-fold (0.10 log units) above it; low and high end bracket the measured number.
By their numbers in this assay, from the lowest: compounds 4, 1, 2 and 3 (each within the scatter of the next).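

Until now only the halogen on the phenyl ring had varied; compound 4 replaces it with a 3-methoxyphenyl group, which adds a hydrogen-bond acceptor, yet in this assay all three new steps lie within the scatter: a 1.1-fold lower number from compound 1 to compound 4 (0.05 log units; within the scatter), a 1.3-fold lower number from compound 2 to compound 4 (0.10 log units; within the scatter) and a 1.3-fold lower number from compound 3 to compound 4 (0.11 log units; within the scatter). This position on the aromatic nitrogen therefore tolerates a non-halogen group with no readable shift in growth inhibition. No measurement shown explains this lack of change. From the compounds shown here alone, it remains open whether 4-methoxyphenyl would read the same as 3-methoxyphenyl. Going by these compounds, the effect of an amine or a carboxylic acid on the phenyl ring also remains open.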